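Cyanoguanidine series: chain change from compound 2 to compound 3

The source may report more compounds than this note shows. Statements on the series, on what has been measured and on what is new or still open speak of the compounds shown alone.

Measured so far:
compound 1 `N#CNC(=N)NCCCCn1nc(-c2ccccc2)ccc1=O`, 59.3 mg/kg
compound 2 `C/N=C(\NC#N)NCCCCn1nc(-c2ccccc2)ccc1=O`, 38.5 mg/kg

Compound 1 `N#CNC(=N)NCCCCn1nc(-c2ccccc2)ccc1=O` is measured in a functional assay on the whole organism with Rattus norvegicus as the target (on this read-out lower numbers stand for an effect already at smaller amounts and higher numbers for an effect only at larger amounts of compound), at 59.3 mg/kg. Compound 2 `C/N=C(\NC#N)NCCCCn1nc(-c2ccccc2)ccc1=O`, which carries the group of 6 heavy atoms on the amine nitrogen, gives 38.5 mg/kg in this assay. Going by the values given here, the only step between measured compounds is a 1.5-fold lower number from compound 1 to compound 2 (0.19 log units; within the scatter), so compound 2 holds the lower of the two numbers, but the two values stand within the scatter of each other and no order can be drawn from them.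

Compound 3 `C/N=C(/NC#N)NCCCn1nc(-c2ccccc2)ccc1=O` is not yet measured. It differs from compound 2 by a group of 7 heavy atoms (3 carbon, 4 nitrogen; no ring) in place of a group of 8 heavy atoms (4 carbon, 4 nitrogen; no ring), on a saturated chain carbon, three bonds along the chain from an aromatic nitrogen. Among the compounds with values here, the one measured step concerns the amine nitrogen, not the saturated chain, and it is itself within the scatter; no measured step bears on the chain. The expectation is therefore no step beyond the scatter: compound 3 is estimated at 40 mg/kg (range 15 mg/kg to 110 mg/kg) in this assay, which means an expected step of a 1.0-fold higher number from compound 2 to compound 3 (0.02 log units; within the scatter).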

Compound 3, dose for half-maximal effect: 78.1 mg/kg
The estimate for compound 3 lay 2.0-fold (0.29 log units) below the measured number; the measured number falls inside the stated range.
By their numbers in this assay, from the lowest: compounds 2, 1 and 3 (each within the scatter of the next, the first and the last beyond it).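

In this assay, going by these compounds alone, the saturated chain is the first place where a change reaches beyond the scatter: the group of 7 heavy atoms in place of the group of 8 heavy atoms, on a saturated chain carbon, three bonds along the chain from an aromatic nitrogen, gives a 2.0-fold higher number from compound 2 to compound 3 (0.31 log units; beyond the scatter). This step is modest and rests on a single pair, whereas the change on the amine nitrogen stayed within the scatter, and a 1.3-fold higher number from compound 1 to compound 3 (0.12 log units; within the scatter) also stays within it, so compound 1 and compound 3 cannot be ordered and only compound 2 and compound 3 stand apart. No measurement available here accounts for the step at this chain position.

With only these two chain groups on the shared core, the compounds shown cannot tell whether a longer chain would continue this direction, hold the number near that of compound 2 or reverse it. As far as these compounds go, it also remains open whether the chain step would hold with a urea or a thiourea in place of the cyanoguanidine.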